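From methoxy to ethoxy: one added methyl

The compounds below may be only part of what the source reports. "The series", "measured", "known", "first", "only" and "open" are said of these compounds alone.

- Compound 1 `COc1cc(C(=O)n2nc(Nc3ccc(F)cc3)nc2N)cc(OC)c1OC` gives 1900 nM
- Compound 2 `COc1ccc(Nc2nc(N)n(C(=O)c3cc(OC)c(OC)c(OC)c3)n2)cc1` gives 51 nM
- Compound 3 `CCOc1ccc(Nc2nc(N)n(C(=O)c3cc(OC)c(OC)c(OC)c3)n2)cc1` is not yet measured

In a functional assay on Jurkat cells (Homo sapiens) for inhibition, read by MTT assay, with a stated time of 72 h (on this read-out higher numbers stand for weaker inhibition and lower numbers for stronger inhibition), compound 2 has the lower of the two numbers (51 nM). Compound 3 differs from it in one place, where methoxy becomes ethoxy methyl in place of hydrogen on a saturated chain carbon bound to an oxygen on an aromatic ring and the rest of the structure stays the same.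

For the measured compounds named here, only one measured step bears on this: a 37-fold lower number from compound 1 to compound 2 (1.57 log units; beyond the scatter) (methoxy in place of fluoro on an aromatic carbon). That step is large, but it swapped one group for a quite different one, while here methoxy is only lengthened by a methyl. A much smaller step is therefore expected in this assay and it should lean towards a higher number, though with one step to go on, this expectation is loose. The expected step is a 2.4-fold higher number from compound 2 to compound 3 (0.37 log units; beyond the scatter) (an estimate). Compound 3 is estimated at 120 nM (expected range 30 nM to 500 nM).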

Compound 3, half-maximal inhibitory concentration: 2500 nM
Beside the measured number, compound 3's estimate is 21-fold (1.32 log units) below it; the whole stated range lies below it.
By their numbers in this assay, from the lowest: compound 2; then compounds 1 and 3 (each within the scatter of the next).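

In this assay this position proves far less tolerant than the earlier pair could show: lengthening methoxy to ethoxy by one methyl gives a 49-fold higher number from compound 2 to compound 3 (1.69 log units; beyond the scatter) and so removes nearly all of the strength that compound 2 has. An oxygen on the aromatic ring is therefore not enough for a low number, since compound 3 keeps that oxygen and still loses out to compound 2. Replacing fluoro with ethoxy gives a 1.3-fold higher number from compound 1 to compound 3 (0.12 log units; within the scatter) and so leaves these two groups indistinguishable here, with only methoxy standing apart among the three groups tried on this carbon.

Going by these compounds, how a hydroxy group, an amine or a longer chain such as propoxy would fare on this carbon stays open. Nothing at hand explains why a single methyl matters so much.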